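Urea in place of benzothiazole: cytotoxicity working notes

The source may hold more compounds than are shown below. What is called first, only, known or untested is meant among the compounds shown, and "the series" means these compounds.

Measured:
compound 1 `Cc1ccc(-c2c(C)nc(Nc3nc4ccccc4s3)c(C)c2C(OC(C)(C)C)C(=O)O)cc1C` — 6600 nM
compound 2 `Cc1nc(NC(=O)NC2CCCCC2)c(C)c(C(OC(C)(C)C)C(=O)O)c1-c1ccc2c(c1)NCCO2` — 30000 nM

In an ADME assay on MT4 cells (Homo sapiens) for cytotoxicity, read by MTT assay (a higher number here means that more compound is tolerated, a lower number that less compound is tolerated), compound 1 holds the lower of the two numbers; compound 2 stands higher, a gap beyond the scatter. Compound 3 `Cc1ccc(-c2c(C)nc(NC(=O)Nc3ccccc3)c(C)c2C(OC(C)(C)C)C(=O)O)cc1C` keeps the core of compound 1 with one change: phenylcarbamoyl in place of 1,3-benzothiazol-2-yl on a nitrogen on an aromatic ring. Among the measured compounds shown here, no measured step for this change exists. A small upward step is expected, a 1.8-fold higher number from compound 1 to compound 3 (0.26 log units; within the scatter), though it may stay within the scatter. Compound 3 is estimated at 12000 nM, with a range from 5000 nM to 30000 nM.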

Compound 3, half-maximal cytotoxic concentration: 9900 nM
Compound 3: middle estimate off by 1.2-fold (0.08 log units), on the high side; measured number inside the range.
By their numbers in this assay, from the lowest: compounds 1 and 3 (each within the scatter of the next); then compound 2.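

In this assay, phenylcarbamoyl in place of 1,3-benzothiazol-2-yl on a nitrogen on an aromatic ring gives a 1.5-fold higher number from compound 1 to compound 3 (0.18 log units; within the scatter). On the core of compound 1, this read-out therefore does not separate the two groups at this position, although the change removes the five-membered aromatic ring and adds a hydrogen-bond donor. No supporting measurement offers an explanation for this result.

Still open, on these data alone, is how an acetyl group or a pyridyl urea on this nitrogen would read. A free amine at the same place also remains untested within the compounds shown.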